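The source may report more compounds than this note shows. Statements on the series, on what has been measured and on what is new or still open speak of the compounds shown alone.

Compound 1 `Cc1c(C(=O)N/N=C\c2cc(O)ccc2O)oc2cccc(O)c12` gives 95500 nM in a functional assay on PC-3 cells (Homo sapiens) for inhibition; on this read-out lower numbers stand for stronger inhibition and higher numbers for weaker inhibition.
Compound 2 `Cc1ccc(O)c(/C=N\NC(=O)c2oc3cccc(O)c3c2C)c1` gives 7350 nM in this assay.
Compound 3 `Cc1c(C(=O)N/N=C\c2ccc(C(F)(F)F)cc2)oc2cccc(O)c12` gives >= 40000 nM in this assay, a limit of the measurement and not a number.

Compound 3 therefore stands at the limit of >= 40000 nM in this assay, at which 1 of the 3 values shown sits, and among the three compounds it can only be read as weak. Compound 4 `Cc1c(C(=O)N/N=C\c2ccccc2)oc2cccc(O)c12` differs from compound 3 by hydrogen in place of trifluoromethyl on an aromatic carbon. Among the measured compounds shown here, the one measured step, a 13-fold lower number from compound 1 to compound 2 (1.11 log units; beyond the scatter), concerns a hydroxy on the other aromatic ring, so it gives no guidance on removing a trifluoromethyl. With nothing measured pointing in either direction, the expected step is a number no higher from compound 3 to compound 4 (the limit leaves the size open), that is, compound 4 is expected to remain weak. The estimate for compound 4 in this assay is 40000 nM, with a range from 10000 nM to 150000 nM.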

Compound 4, half-maximal inhibitory concentration: 29200 nM
For compound 4 the middle estimate is 1.4-fold (0.14 log units) above the measured one; the measured number falls inside the stated range.
By their numbers in this assay, from the lowest: compound 2; then compound 4; then compound 1.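

Compound 3 is known only through a limit of the assay: the limit of >= 40000 nM in this assay, at which 1 of the 4 values shown sits. Taking the trifluoromethyl off therefore gives only an at least 1.3-fold lower number from compound 3 to compound 4 (0.13 log units; that floor lies within the scatter), which shows no clear effect of this change. The bare phenyl now serves as a reference for the other ring, and substituents on it can go either way: there is a 4.0-fold higher number from compound 2 to compound 4 (0.60 log units; beyond the scatter), but also a 3.3-fold lower number from compound 1 to compound 4 (0.51 log units; beyond the scatter).

On these data alone, how an amine or a carboxylic acid would behave in place of the trifluoromethyl remains open. So does the effect of a methyl or a hydroxy alone on that ring.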